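The source may report more compounds than this note shows. Statements on the series, on what has been measured and on what is new or still open speak of the compounds shown alone.

Among the measured compounds shown here, in a functional assay on HCT-116 cells (Homo sapiens) for antiproliferative activity, read by MTT assay, with a stated time of 48 h (a higher number here means a weaker inhibitor of growth, a lower number a stronger inhibitor of growth), compound 1 (`S=C(Nc1ccccc1)N1N=C(c2ccc(Br)cc2)CC1c1ccc2c(c1)OCCO2`) gives 32100 nM, the only exact number so far. For compound 2 (`COc1cccc(C2=NN(C(=S)Nc3ccccc3)C(c3ccc4c(c3)OCCO4)C2)c1`), which carries 3-methoxyphenyl in place of 4-bromophenyl, the assay reports only a limit, > 200000 nM.

Compound 3 (`S=C(Nc1ccccc1)N1N=C(c2ccc(OCc3ccccc3)cc2)CC1c1ccc2c(c1)OCCO2`) keeps the core of compound 1 and changes one group: benzyloxy in place of bromo on an aromatic carbon. The new benzyloxy sits on an aromatic carbon, para to a large group.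

For the measured compounds named here, one measured step bears on this change, and it also removes the bromo and brings in an oxygen-linked group. That step is an at least 6.2-fold higher number from compound 1 to compound 2 (0.79 log units; beyond the scatter), which lies beyond the scatter. On these data alone, its true size remains open, since it ends at the limit of > 200000 nM in this assay, at which 1 of the 2 values shown sits. It is also thin evidence. Compound 2 differs from compound 3 in both the group and its place on the ring. A modest move towards weaker growth inhibition in this assay therefore seems more likely than a gain. The expected step is a 2.2-fold higher number from compound 1 to compound 3 (0.34 log units; beyond the scatter). Compound 3 is estimated at 70000 nM, with an expected range from 18000 nM to 200000 nM.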

Compound 3, concentration for 50% growth inhibition: 8530 nM
Beside the measured number, compound 3's estimate is 8.2-fold (0.91 log units) above it; measured number below the stated range.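

At this position, para to a large group, the bromo of compound 1 can be replaced by benzyloxy, with 8 heavy atoms and a six-membered aromatic ring, and growth inhibition in this assay becomes stronger: the result is a 3.8-fold lower number from compound 1 to compound 3 (0.58 log units; beyond the scatter). The only earlier step at this ring, an at least 6.2-fold higher number from compound 1 to compound 2 (0.79 log units; beyond the scatter), pointed the other way, so among the compounds shown, an oxygen-linked group does not always go with weaker growth inhibition. Compound 2 gives only a limit, so the size of that earlier step remains unfixed, and its oxygen-linked group also sits at a different place on the ring: the limit of > 200000 nM in this assay, at which 1 of the 3 values shown sits.

A single replacement cannot show whether the stronger growth inhibition of compound 3 goes with the oxygen link, the added aromatic ring or the overall length of the benzyloxy group. A phenoxy group, a benzylamino group or a carboxylic acid at this same position would help to separate these possibilities, and a second cell line would show whether the step holds beyond this assay.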